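A few compounds are considered here, and "the series" means these few. Any claim that something is new, unique, unknown or untested is made for them only; others in the source may bear on it.

Measured so far in a physicochemical assay for solubility, read by spectrophotometry, using the shake flask method, with a stated time of 2 days, at pH 6.5; a lower number here means a less soluble compound, a higher number a more soluble compound:
compound 1 `O=C(O)COc1ccc2nc(-c3cn(-c4ccc(O)cc4)nn3)ccc2c1` gives 365 ug/mL
compound 2 `OCCOc1ccc2nc(-c3cn(-c4ccc(O)cc4)nn3)ccc2c1` gives 2.6 ug/mL
compound 3 `NCCOc1ccc2nc(-c3cn(-c4ccc(O)cc4)nn3)ccc2c1` gives 3.7 ug/mL

Compound 3 stands at the low end of these three numbers. The measured steps to it are a 1.4-fold higher number from compound 2 to compound 3 (0.15 log units; within the scatter) and a 99-fold lower number from compound 1 to compound 3 (1.99 log units; beyond the scatter), the first within the scatter and the second large.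

Compound 4 `COCCOCCOc1ccc2nc(-c3cn(-c4ccc(O)cc4)nn3)ccc2c1` differs from compound 3 as follows: 2-methoxyethoxy in place of amino on a saturated chain carbon, two bonds along the chain from an oxygen on an aromatic ring and so it ends in 2-(2-methoxyethoxy)ethoxy in place of 2-aminoethoxy.

Two large steps are on record, a 140-fold lower number from compound 1 to compound 2 (2.15 log units; beyond the scatter) and a 99-fold lower number from compound 1 to compound 3 (1.99 log units; beyond the scatter), and both remove the carboxy group of compound 1. Compound 4 has no carboxy group either, so these two steps do not set the size of this change. The closest guide is a 1.4-fold higher number from compound 2 to compound 3 (0.15 log units; within the scatter), an exchange at the same chain carbon that stays within the scatter. For the measured compounds named here, no measured compound carries the 2-methoxyethoxy group, so the range stays fairly wide. No step beyond the scatter is expected in this assay in either direction, and the estimated step is a 1.1-fold higher number from compound 3 to compound 4 (0.03 log units; within the scatter) at the middle of that range. Compound 4 is expected at 4 ug/mL within an estimated range of 1.5 ug/mL to 12 ug/mL when it is measured.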

Compound 4, solubility: 2.4 ug/mL
For compound 4 the middle estimate is 1.7-fold (0.22 log units) above the measured one; low and high end bracket the measured number.
By their numbers in this assay, from the lowest: compounds 4, 2 and 3 (each within the scatter of the next); then compound 1.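

In this assay, the much larger 2-(2-methoxyethoxy)ethoxy chain end gives a 1.5-fold lower number from compound 3 to compound 4 (0.19 log units; within the scatter) when it replaces 2-aminoethoxy, and adding 2-methoxyethyl on the oxygen of the hydroxy group gives a 1.1-fold lower number from compound 2 to compound 4 (0.03 log units; within the scatter). Here 5 heavy atoms and 0 hydrogen-bond donors enter where 1 heavy atom and 1 hydrogen-bond donor leave, so at this position neither the longer chain nor the absence of a donor at its end takes the number beyond the scatter, whether the comparison starts from the amino or the hydroxy compound. The step to the carboxy compound remains large, with a 150-fold lower number from compound 1 to compound 4 (2.18 log units; beyond the scatter), so among these four compounds, compound 1 alone stands apart, while compounds 2, 3 and 4 lie within the scatter of one another. Nothing shown here gives a measured reason why these three chain ends read alike.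

The compounds shown leave open whether a longer chain ending in a carboxylic acid, or a sulfonic acid in its place, would read like compound 1. They also leave open whether a methyl ester of compound 1 or a morpholine at the chain end would fall with compounds 2, 3 and 4.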